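A few compounds are considered here, and "the series" means these few. Any claim that something is new, unique, unknown or untested is made for them only; others in the source may bear on it.

Measured compounds:
- compound 1, `NC(=O)c1cccc2[nH]c(-c3ccccn3)nc12`: 224 uM in an ADME assay on Vero cells (Chlorocebus sabaeus) for cytotoxicity; on this read-out lower numbers stand for higher toxicity in this test and higher numbers for lower toxicity in this test
- compound 2, `O=C(Nc1ccccc1)c1cccc2[nH]c(-c3ccccn3)nc12`: 17.9 uM in this assay

Among the measured compounds shown here, compound 2 holds the lowest of the two numbers so far; its nearest neighbour is compound 1, from which it is separated by a 13-fold lower number from compound 1 to compound 2 (1.10 log units; beyond the scatter), a change of phenyl in place of hydrogen on an amide-type nitrogen.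

Compound 3, `O=C(Nc1ccccc1F)c1cccc2[nH]c(-c3ccccn3)nc12`, is the next step out from compound 2. The difference is fluoro in place of hydrogen on an aromatic carbon, that is, phenyl becomes 2-fluorophenyl, on an aromatic carbon of the six-membered carbon-only ring, ortho to a large group. For the measured compounds named here, no measured pair alters the aryl ring itself; the single measured step concerns growing the amide from hydrogen to phenyl and is of another kind, so it offers no direct guide. A single fluoro on an existing ring is a small edit compared with that step.

With nothing pointing either way, compound 3 is expected to stay near compound 2, the estimated step being a 1.1-fold lower number from compound 2 to compound 3 (0.05 log units; within the scatter), within the scatter. The estimate for compound 3 in this assay is 16 uM, with a range of 6 uM to 40 uM.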

Compound 3, half-maximal toxic concentration: 54.7 uM
Compound 3: middle estimate off by 3.4-fold (0.53 log units), on the low side; measured number outside the range, above it.
By their numbers in this assay, from the lowest: compound 2; then compound 3; then compound 1.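

In this assay the aromatic carbon ortho to a large group on the anilide phenyl ring proves sensitive to a very small edit: fluoro in place of hydrogen gives a 3.1-fold higher number from compound 2 to compound 3 (0.49 log units; beyond the scatter) and so moves the series back toward lower toxicity in this test, which the earlier pair, concerned only with adding the phenyl, could not show. The gain is partial, since the step of a 13-fold lower number from compound 1 to compound 2 (1.10 log units; beyond the scatter) is only partly offset and 2-fluorophenyl on the amide nitrogen still leaves a 4.1-fold lower number from compound 1 to compound 3 (0.61 log units; beyond the scatter) as a change beyond the scatter. Nothing available explains why this single fluoro shifts the read-out, so the observation stands without a cause.

Still open, going by these compounds, is whether the shift belongs to fluoro itself or to any group at this place, which chloro, methyl or methoxy on the same carbon would test, as would fluoro moved to another carbon of the ring. On these data alone, it is also open whether an amine or a carboxylic acid on the phenyl ring, or a short alkyl chain in place of the phenyl on the amide nitrogen, would bring the number closer to that of compound 1 at 224 uM in this assay.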